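Replacing the hexyl chain with 3,7-dimethylocta-2,6-dien-1-yl

This account rests on a few compounds, and the source may have more. Where it says the series, first, only, none or still open, it means among the compounds named here.

In a functional assay on MCF7 cells (Homo sapiens) for inhibition, read by fluorescence, with a stated time of 72 h (on this read-out higher numbers stand for weaker inhibition of growth and lower numbers for stronger inhibition of growth), compound 1 `CCCCCCn1cnc2c(Nc3ccc(Cl)cc3)nc(N[C@H]3CC[C@H](N)CC3)nc21` gives 4200 nM and compound 2 `CCCCCCn1cnc2c(Nc3cccc(Cl)c3)nc(N[C@H]3CC[C@H](N)CC3)nc21` gives 2700 nM. These two numbers lie within the scatter of each other, so compound 2 stands level with compound 1. Compound 3 `CC(C)=CCC/C(C)=C/Cn1cnc2c(Nc3cccc(Cl)c3)nc(N[C@H]3CC[C@H](N)CC3)nc21` alters compound 2 only in its chain: 2,6-dimethylhepta-1,5-dien-1-yl in place of pentyl on a saturated chain carbon bound to an aromatic nitrogen. Cut one bond further out, this reads hexyl to 3,7-dimethylocta-2,6-dien-1-yl. Going by the values given here, the only measured step, a 1.6-fold lower number from compound 1 to compound 2 (0.19 log units; within the scatter), is 3-chlorophenyl in place of 4-chlorophenyl, so it leaves the chain untouched and offers no guide to this change. No chain change has been measured, so no step beyond the scatter is expected in this assay, and no direction can be favoured. The expected result is a 1.2-fold lower number from compound 2 to compound 3 (0.09 log units; within the scatter). Compound 3 is estimated at 2200 nM, with an expected range of 700 nM to 6500 nM.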

Compound 3, concentration for 50% growth inhibition: 3600 nM
Beside the measured number, compound 3's estimate is 1.6-fold (0.21 log units) below it; low and high end bracket the measured number.
By their numbers in this assay, from the lowest: compounds 2, 3 and 1 (each within the scatter of the next).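

In this assay the chain on the aromatic nitrogen gives the first view of this position: pentyl gives way to 2,6-dimethylhepta-1,5-dien-1-yl, with 9 heavy atoms in place of 5 and 2 double bonds, and the result is a 1.3-fold higher number from compound 2 to compound 3 (0.12 log units; within the scatter) and no more. Compound 2 and compound 3 therefore stand level, which shows that this position accepts the larger, unsaturated chain with no change beyond the scatter in this growth read-out. Nothing available explains why the two compounds stand level.

The compounds shown leave open whether a chain ending in an amine or a carboxylic acid, or a short chain such as methyl, would also stand level. They also leave open whether 3,7-dimethylocta-2,6-dien-1-yl would behave the same way alongside 4-chlorophenyl.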